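Working notes: amine substituent exchange on the shared core

A few compounds are considered here, and "the series" means these few. Any claim that something is new, unique, unknown or untested is made for them only; others in the source may bear on it.

Compound 3 `Nc1nn2c(O)cc(CNCCO)nc2c1[N+](=O)[O-]` carries the ((2-hydroxyethyl)amino)methyl group on the shared core. In a functional assay on L929 cells (Mus musculus) for inhibition (a lower number here means a stronger inhibitor of growth, a higher number a weaker inhibitor of growth), compound 3 gives > 50 ug/mL, which is a limit of the assay and not a number. Compound 1 `Nc1nn2c(O)cc(-c3ccccc3F)nc2c1[N+](=O)[O-]` gives in this assay > 50 ug/mL, again a limit. Compound 2 `Nc1nn2c(O)cc(CCl)nc2c1[N+](=O)[O-]` gives in this assay > 50 ug/mL, also a limit. All three values therefore sit at the limit of > 50 ug/mL in this assay, at which 3 of the 3 values shown sit, and the steps between them stay unreadable: a step that the two limits leave unreadable from compound 1 to compound 3, a step that the two limits leave unreadable from compound 2 to compound 3 and a step that the two limits leave unreadable from compound 1 to compound 2.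

Compound 4 `CCSC(N)NCc1cc(O)n2nc(N)c([N+](=O)[O-])c2n1` is the next member, differing from compound 3 by amino(ethylsulfanyl)methyl in place of 2-hydroxyethyl on an amine nitrogen. For the measured compounds named here, no measured step bears on this change with a readable size; the only bearing is that every measured member sits at the limit. Compound 4 is therefore expected to sit at the limit as well, with an estimated value of 80 ug/mL in the range 30 ug/mL to 250 ug/mL. The step that the limit leaves unreadable from compound 3 to compound 4 is expected to be none beyond the scatter.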

Compound 4, concentration for 50% growth inhibition: > 50 ug/mL
Compound 4: only a limit was reported; the forecaster's own chance of this, stated with the estimate: 85%; the middle value does not contradict the limit.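

In this assay compound 4 gives > 50 ug/mL, a limit and not a number, so its steps from compound 1, compound 2 and compound 3 cannot be read: the limit of > 50 ug/mL in this assay, at which 4 of the 4 values shown sit.

The compounds shown leave open which substituent on the shared core, if any, gives a readable value in this assay.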